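The compounds below may be only part of what the source reports. "The series", "measured", "known", "first", "only" and "open" are said of these compounds alone.

Compound 1 `Cn1c(-c2ccccc2)cnc1NC(=O)c1ccccc1` gives > 100000 nM in a toxicity assay on THP-1 cells (Homo sapiens) for inhibition (on this read-out higher numbers stand for lower toxicity in this test and lower numbers for higher toxicity in this test), which is a limit of that test. Compound 2 `COc1ccc(-c2cnc(NC(=O)c3ccn[nH]3)n2C)cc1` gives > 100000 nM, again a limit. Compound 3 `COc1ccc(-c2cnc(NC(=O)c3cc(-c4ccccn4)n[nH]3)n2C)cc1` gives >= 50000 nM, also a limit.

Compound 2 therefore stands at a limit, and the two other measured values are limits as well. Among the compounds with values here, the only measured step, a step that the two limits leave unreadable from compound 2 to compound 3, puts pyridin-2-yl in place of hydrogen on an aromatic carbon, and its size is not readable. Compound 4 `CCC(=O)Nc1ncc(-c2ccc(OC)cc2)n1C` differs from compound 2 in one place: ethyl in place of 1H-pyrazol-5-yl on a carbonyl carbon. Within the data shown here, no measured step touches the carbonyl substituent. Since every value shown sits at a limit (the limit of > 100000 nM in this assay, at which 2 of the 3 values shown sit, (the limit of >= 50000 nM in this assay, at which 1 of the 3 values shown sits)), compound 4 is expected to remain there too, and a number no higher from compound 2 to compound 4 (the limit leaves the size open) is estimated as none beyond the scatter. Compound 4 is estimated at 100000 nM, within 40000 nM to 250000 nM.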

Compound 4, half-maximal cytotoxic concentration: > 100000 nM
Compound 4: no number, only a limit (the forecaster's own chance of this, stated with the estimate: 80%); the middle value sits exactly at the limit.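

In this assay, within the data shown here, compound 4 gives > 100000 nM, which is a limit, so no step from compound 2 to compound 4 can be read. The compounds shown leave open where any half-maximal cytotoxic concentration actually lies.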